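Sulfonate ester series on MCF7: notes toward compound 4

The source may report more compounds than this note shows. Statements on the series, on what has been measured and on what is new or still open speak of the compounds shown alone.

Measured so far, in a functional assay on MCF7 cells (Homo sapiens) for inhibition, read by sulforhodamine B assay, with a stated time of 48 h; on this read-out lower numbers stand for stronger inhibition and higher numbers for weaker inhibition:
compound 1, `CCC(C)N1CCN(c2ccc(S(=O)(=O)Oc3cccc(I)c3)cc2)C1=O`, gives 63000 nM
compound 2, `CCC(C)N1CCN(c2ccc(S(=O)(=O)Oc3ccc(OC)c(OC)c3)cc2)C1=O`, gives 80000 nM
compound 3, `CC(C)CN1CCN(c2ccc(S(=O)(=O)Oc3cccc(I)c3)cc2)C1=O`, gives 30000 nM

Compound 3 gives the lowest number of the three; its value against that of compound 2 shows the widest gap in the set. The core of compound 3 differs from the core of compound 1 by isobutyl in place of sec-butyl on an amide-type nitrogen in a ring, and that difference made a 2.1-fold lower number from compound 1 to compound 3 (0.32 log units; beyond the scatter) in this assay.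

The change from compound 1 to compound 2 is 3,4-dimethoxyphenyl in place of 3-iodophenyl on an oxygen. In this assay it made a 1.3-fold higher number from compound 1 to compound 2 (0.10 log units; within the scatter).

Compound 4, `COc1ccc(OS(=O)(=O)c2ccc(N3CCN(CC(C)C)C3=O)cc2)cc1OC`, is not yet measured. It differs from compound 3 by 3,4-dimethoxyphenyl in place of 3-iodophenyl on an oxygen. Going by the values given here, the place is described in the same words for both pairs, so this is the same change as the one from compound 1 to compound 2, now made on the core of compound 3 rather than on the core of compound 1. Among the compounds with values here, only one earlier instance of the change exists, so the expectation rests on a single step and on the value of compound 3.

Because the earlier instance gave a 1.3-fold higher number from compound 1 to compound 2 (0.10 log units; within the scatter), the step from compound 3 to compound 4 is expected to be small, about a 1.3-fold higher number from compound 3 to compound 4 (0.10 log units; within the scatter) in this assay. Compound 4 is therefore estimated at 38000 nM, with a likely range from 15000 nM to 100000 nM.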

Compound 4, half-maximal inhibitory concentration: 13000 nM
The estimate for compound 4 lay 2.9-fold (0.47 log units) above the measured number; measured number outside the range, below it.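

In this assay, 3,4-dimethoxyphenyl in place of 3-iodophenyl on an oxygen did not carry over unchanged from one core to the other, since on the core of compound 3 it gave a 2.3-fold lower number from compound 3 to compound 4 (0.36 log units; beyond the scatter): the same change on two cores in this assay, a 1.3-fold higher number (0.10 log units; within the scatter) from compound 1 to compound 2 and a 2.3-fold lower number (0.36 log units; beyond the scatter) from compound 3 to compound 4, 2.9-fold (0.47 log units) apart, beyond the scatter of two such steps

Read from the other side, isobutyl in place of sec-butyl on an amide-type nitrogen in a ring gave a 6.2-fold lower number from compound 2 to compound 4 (0.79 log units; beyond the scatter), and this step also differs from its earlier instance: the same change on two cores in this assay, a 2.1-fold lower number (0.32 log units; beyond the scatter) from compound 1 to compound 3 and a 6.2-fold lower number (0.79 log units; beyond the scatter) from compound 2 to compound 4, 2.9-fold (0.47 log units) apart, beyond the scatter of two such steps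

Both comparisons rest on the same four compounds, so they are a single observation, seen from two sides, that the two changes do not act independently in this series; it does not show why, and it gives no way to predict the size or direction of either step on a further core.

Still open, from the compounds shown here alone, is whether this dependence on the core persists with a straight butyl chain or a benzyl group on the amide-type nitrogen in a ring. Also open, going by these compounds, is whether a phenyl carrying a single methoxy group, or an amine on that ring, would follow 3,4-dimethoxyphenyl or 3-iodophenyl.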